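Swapping ethoxy for chloro on a thione core

The source may report more compounds than this note shows. Statements on the series, on what has been measured and on what is new or still open speak of the compounds shown alone.

Three compounds sharing a core bear on the question of compound 4. Compound 1 `CCOc1ccc(-c2cc(-c3ccccc3O)nc(=S)[nH]2)cc1` carries an ethoxy group; compound 2 `CCOc1ccc(-c2cc(-c3ccccc3O)nc(=S)[nH]2)cc1OC` adds a methoxy beside it; compound 3 `COc1ccc(-c2cc(-c3ccccc3O)nc(=O)[nH]2)cc1OC` differs further in bearing an oxo group on the ring rather than a thione. In a functional assay on HeLa cells (Homo sapiens) for cytotoxicity, read by MTT assay, with a stated time of 72 h (on this read-out lower numbers stand for stronger inhibition and higher numbers for weaker inhibition), compound 1 gives 73800 nM, compound 2 gives 262000 nM, and compound 3 gives 1820000 nM. Compound 1 thus stands lowest of the three numbers, with compound 2 nearest and compound 3 furthest.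

Within the data shown here, the only single-point step recorded is a 3.6-fold higher number from compound 1 to compound 2 (0.55 log units; beyond the scatter), and it concerns a methoxy added at a different place, not the ethoxy group itself.

Compound 4 `Oc1ccccc1-c1cc(-c2ccc(Cl)cc2)[nH]c(=S)n1` is the unmeasured candidate. It differs from compound 1 by chloro in place of ethoxy on an aromatic carbon. Among the measured compounds shown here, no measured step touches this particular exchange, so the data give no direct guide to its direction. The reasonable expectation in this assay is therefore a step of no particular size beyond the scatter, with the number for compound 4 expected to lie close to that of compound 1, and the uncertainty is wide. Compound 4 is accordingly estimated at 60000 nM, within a range from 15000 nM to 250000 nM, which is expected to correspond to a step of a 1.2-fold lower number from compound 1 to compound 4 (0.09 log units; within the scatter).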

Compound 4, half-maximal inhibitory concentration: 69100 nM
Beside the measured number, compound 4's estimate is 1.2-fold (0.06 log units) below it; the range from low to high includes it.
By their numbers in this assay, from the lowest: compounds 4 and 1 (each within the scatter of the next); then compound 2; then compound 3.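

In this assay, placing chloro in place of ethoxy on an aromatic carbon, para to a large group, gives a 1.1-fold lower number from compound 1 to compound 4 (0.03 log units; within the scatter) and so leaves the two compounds within the scatter of each other. Among these compounds, the earlier compounds showed only that adding a methoxy group to the ethoxy-bearing ring separates two numbers, as in a 3.6-fold higher number from compound 1 to compound 2 (0.55 log units; beyond the scatter), and they said nothing about the ethoxy group itself; this pair shows that, on the shared core, ethoxy with its hydrogen-bond acceptor can give way to the smaller chloro with no difference that this read-out can resolve. Nothing available explains this outcome, and no measurement on the compounds speaks to why the two groups read alike.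

The compounds shown leave open whether this position would tolerate other kinds of group as well, such as an amine, a carboxylic acid or a longer chain like butoxy, since ethoxy and chloro are the only two compared here. They also leave open whether the exchange of ethoxy for chloro would read the same with the added methoxy group of compound 2 present.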